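Adding a Chloro Group to Compound 3

The compounds below may be only part of what the source reports. "The series", "measured", "known", "first", "only" and "open" are said of these compounds alone.

Two pairs of compounds share one structural change. Compound 2 `ClCc1ccccc1Cn1cnc2c(Cl)ncnc21` carries a single chloro group on its fused two-ring core, while compound 1 `ClCc1ccccc1Cn1cnc2c(Cl)nc(Cl)nc21` carries a second one. In a functional assay on UO-31 cells (Homo sapiens) for cytotoxicity, read by sulforhodamine B assay, with a stated time of 48 h (on this read-out higher numbers stand for weaker inhibition of growth and lower numbers for stronger inhibition of growth), compound 2 gives 10500 nM, and compound 1 gives 1510 nM. The change, (chloro in place of hydrogen on an aromatic carbon), produced a 7.0-fold lower number from compound 2 to compound 1 (0.84 log units; beyond the scatter).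

Compound 3 `ClCc1cccc(Cn2cnc3c(Cl)ncnc32)c1` is built from the same atoms as compound 2, joined differently; the difference between the two cores is not broken down here. In this assay compound 3 gives 36300 nM, the highest number of the three measured compounds. Compound 4 `ClCc1cccc(Cn2cnc3c(Cl)nc(Cl)nc32)c1`, not yet measured, is compound 3 with the same change applied: chloro in place of hydrogen on an aromatic carbon. The place of the change is described in identical words for both pairs, so it is the same change, only made on a different core.

For the measured compounds named here, the expectation for compound 4 rests on a single measured example, because the only step of this kind is a 7.0-fold lower number from compound 2 to compound 1 (0.84 log units; beyond the scatter), and a change seen once on one core need not carry over to another unchanged. With that caution, the step from compound 3 to compound 4 is expected to be roughly a 6.6-fold lower number from compound 3 to compound 4 (0.82 log units; beyond the scatter). In this assay compound 4 is therefore estimated at about 5500 nM, with a plausible range from 1500 nM to 20000 nM.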

Compound 4, concentration for total growth inhibition: 3090 nM
The estimate for compound 4 lay 1.8-fold (0.25 log units) above the measured number; the range from low to high includes it.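

In this assay, chloro in place of hydrogen on the aromatic carbon between two ring nitrogen atoms gives a 12-fold lower number from compound 3 to compound 4 (1.07 log units; beyond the scatter), so the change that strengthened growth inhibition on the core of compound 2 does the same on the core of compound 3. The size of the step also held up from one core to the other, and the small gap between the two steps should not be read as a real difference: the same change on two cores in this assay, a 7.0-fold lower number (0.84 log units; beyond the scatter) from compound 2 to compound 1 and a 12-fold lower number (1.07 log units; beyond the scatter) from compound 3 to compound 4, 1.7-fold (0.23 log units) apart, within the scatter of two such steps. For the compounds shown here, this is still only two cores in a single cell-based read-out, so it shows that the change carried over in this one case, but it does not show that it would do so on any further core, and it does not explain why the number falls.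

The compounds shown have only hydrogen or chloro at this place, so it remains open whether an amine, a methoxy group or a longer chain there would lower the number as well, or raise it. Also open, going by these compounds, is what would happen if the chloromethyl group, which all four compounds carry, gave way to another group such as a carboxylic acid.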